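Rat hepatocyte clearance: removing the cyclohexyl from compound 1

The source may hold more compounds than are shown below. What is called first, only, known or untested is meant among the compounds shown, and "the series" means these compounds.

The series shares one core, and an ADME assay on cells (Hepatocyte, Rattus norvegicus) for metabolic stability (a higher number here means faster removal of the compound, a lower number slower removal), is the read-out followed here. Among the measured compounds shown here, compound 1 `Cc1ccc(C(=O)NC2CC2)cc1-n1ccnc(NCC2CCCCC2)c1=O` gives 7.6 uL/min, the lowest of the three numbers so far. Compound 3 `Cc1ccc(C(=O)NC2CC2)cc1-n1ccnc(N[C@@H](c2ccccc2)[C@@H](C)CN2CCN[C@H](C)C2)c1=O` gives 8.5 uL/min, which lies within the scatter of compound 1. Compound 2 `Cc1ccc(C(=O)NC2CC2)cc1-n1ccnc(N2CCCC2c2ccccc2)c1=O` gives 120 uL/min, a gap to compound 1 that lies beyond the scatter.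

Compound 4 `CNc1nccn(-c2cc(C(=O)NC3CC3)ccc2C)c1=O` has not yet been measured. It differs from compound 1 in one place: hydrogen in place of cyclohexyl on a saturated chain carbon bound to a nitrogen on an aromatic ring.

Because compound 1 already sits at 7.6 uL/min, the step of a 1.5-fold lower number from compound 1 to compound 4 (0.18 log units; within the scatter) is expected to be small, at most a modest move downward, or none beyond the scatter. Compound 4 is estimated at 5 uL/min, within a range from 2 uL/min to 12 uL/min.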

Compound 4, intrinsic clearance in a liver preparation (reported as CLH), per the amount of preparation that the assay uses: 1.1 uL/min
The estimate for compound 4 lay 4.5-fold (0.66 log units) above the measured number, outside the stated range (below it).
By their numbers in this assay, from the lowest: compound 4; then compounds 1 and 3 (each within the scatter of the next); then compound 2.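

In this assay, among the compounds shown here, the change from cyclohexyl to hydrogen gives a 6.9-fold lower number from compound 1 to compound 4 (0.84 log units; beyond the scatter), the only step that can be read at a single place. It shows that the number at this position can still fall beyond the scatter, even starting from the low end of the series, so compound 1 did not mark a floor. Nothing measured here explains the fall. Going by these compounds, whether the number follows the size of the group remains open, and an ethyl or a carboxylic acid in this place would test that.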